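The source may hold more compounds than are shown below. What is called first, only, known or untested is meant among the compounds shown, and "the series" means these compounds.

Measured compounds in a functional assay on MDA-MB-231 cells (Homo sapiens) for antiproliferative activity, read by MTT assay, with a stated time of 72 h; a lower number here means a stronger inhibitor, a higher number a weaker inhibitor:
compound 1 `Cn1ncnc1-c1cc(Oc2ccc(NC(=O)Nc3cccc(C(F)(F)F)c3)cc2F)ccn1`, 9680 nM;
compound 2 `Cn1cnnc1-c1cc(Oc2ccc(NC(=O)Nc3cccc(C(F)(F)F)c3)cc2F)ccn1`, 6470 nM;
compound 3 `CN(C)CCn1cnnc1-c1cc(Oc2ccc(NC(=O)Nc3ccc(Cl)c(C(F)(F)F)c3)cc2F)ccn1`, 1070 nM.

Compound 3 gives the lowest number of the three, with compound 2 nearest and compound 1 furthest, both beyond the scatter. Compound 4 `CN(C)CCn1cnnc1-c1cc(Oc2ccc(NC(=O)Nc3cccc(C(F)(F)F)c3)cc2F)ccn1` differs from compound 3 by hydrogen in place of chloro on an aromatic carbon, that is, 4-chloro-3-(trifluoromethyl)phenyl to 3-(trifluoromethyl)phenyl. Among the compounds with values here, the only measured step, a 1.5-fold lower number from compound 1 to compound 2 (0.17 log units; within the scatter), concerns the triazole and says nothing about this change; compounds 1 and 2 lack the chloro but also differ from compound 3 elsewhere, so no step isolates it. Compound 4 is therefore expected to show a moderately higher number, a step of a 2.3-fold higher number from compound 3 to compound 4 (0.37 log units; beyond the scatter), with an estimate of 2500 nM ranging from 900 nM to 7000 nM.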

Compound 4, half-maximal inhibitory concentration: 16400 nM
Compound 4: the middle estimate sits 6.6-fold (0.82 log units) below what was measured; measured number above the stated range.
By their numbers in this assay, from the lowest: compound 3; then compounds 2, 1 and 4 (each within the scatter of the next, the first and the last beyond it).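

Replacing the chloro of the 4-chloro-3-(trifluoromethyl)phenyl group with hydrogen gives a large step, a 15-fold higher number from compound 3 to compound 4 (1.19 log units; beyond the scatter), so this place, ortho to a trifluoromethyl group, strongly affects the number in this series. Without the chloro, adding (dimethylamino)methyl to the triazole's methyl gives a modest step in the unfavourable direction, a 2.5-fold higher number from compound 2 to compound 4 (0.40 log units; beyond the scatter), while the comparison with the other triazole, a 1.7-fold higher number from compound 1 to compound 4 (0.23 log units; within the scatter), stays within the scatter. Nothing measured here explains these steps. On these data alone, whether fluoro, bromo or methyl could replace the chloro remains open, as does how the (dimethylamino)methyl group behaves when the chloro is present.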